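The source may hold more compounds than are shown below. What is called first, only, known or untested is meant among the compounds shown, and "the series" means these compounds.

Of the compounds shown here, three built on one shared core have been measured so far. Compound 1 `O=C(CSc1nnc(-c2ccncc2)o1)N/N=C/c1ccc(Br)cc1`, compound 2 `O=C(CSc1nnc(-c2ccncc2)o1)N/N=C/c1ccc(O)cc1` and compound 3 `O=C(CSc1nnc(-c2ccncc2)o1)N/N=C/c1ccccc1F` differ only in the aromatic ring that sits on a carbon with a double bond to nitrogen. In a functional assay on MCF7 cells (Homo sapiens) for cytotoxicity, read by MTT assay, with a stated time of 48 h (a lower number here means a stronger inhibitor, a higher number a weaker inhibitor), compound 1 gives 19100 nM, compound 2 gives 11700 nM and compound 3 gives 21800 nM. Compound 3 carries the highest of the three numbers, yet the steps of a 1.1-fold higher number from compound 1 to compound 3 (0.06 log units; within the scatter) and a 1.9-fold higher number from compound 2 to compound 3 (0.27 log units; within the scatter) both lie within the usual scatter, so none of the three can be ranked against the others.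

Compound 4 `O=C(CSc1nnc(-c2ccncc2)o1)N/N=C/c1ccc(Cl)cc1Cl` is the next member of the set: 2,4-dichlorophenyl in place of 2-fluorophenyl on a carbon with a double bond to nitrogen. The measured steps that bear on this change are the two that also exchange the whole ring on that carbon, a 1.1-fold higher number from compound 1 to compound 3 (0.06 log units; within the scatter) and a 1.9-fold higher number from compound 2 to compound 3 (0.27 log units; within the scatter), while a 1.6-fold lower number from compound 1 to compound 2 (0.21 log units; within the scatter) exchanges a single substituent on the ring. All three fall within the scatter, so exchanging one halogenated ring for another is expected to shift the number in this assay by no more than the scatter, with no direction to call. The step expected from this change is a 1.1-fold lower number from compound 3 to compound 4 (0.04 log units; within the scatter). Compound 4 is therefore estimated at 20000 nM, with a range from 8000 nM to 50000 nM.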

Compound 4, half-maximal inhibitory concentration: 27900 nM
The estimate for compound 4 lay 1.4-fold (0.14 log units) below the measured number; low and high end bracket the measured number.
By their numbers in this assay, from the lowest: compounds 2, 1, 3 and 4 (each within the scatter of the next, the first and the last beyond it).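

For the compounds shown here, on the carbon with a double bond to nitrogen, 2,4-dichlorophenyl gives the first step at this position that clears the scatter in this assay, against the 4-hydroxyphenyl of compound 2 (a 2.4-fold higher number from compound 2 to compound 4 (0.38 log units; beyond the scatter)), though the step is modest. The same ring stays within the scatter of the other two rings (a 1.3-fold higher number from compound 3 to compound 4 (0.11 log units; within the scatter); a 1.5-fold higher number from compound 1 to compound 4 (0.16 log units; within the scatter)), so the four compounds do not fall into clear groups: only the two ends of the series can be told apart, while compound 1 and compound 3 cannot be separated from either end. No measurement is available that explains this one difference.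

Compound 2 and compound 4 differ by a whole ring, so these data cannot show whether the step follows the loss of the hydroxy group, the arrival of the two chlorines, or both. Also open, as far as these compounds go, is how this assay would read with an amine or a carboxylic acid on the ring, with a longer chain in place of the ring, or with any change to the rest of the shared core.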